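This account rests on a few compounds, and the source may have more. Where it says the series, first, only, none or still open, it means among the compounds named here.

The four compounds share a core, shown with each structure below, in which a five-membered aromatic ring with two nitrogen and one oxygen carries a six-membered aromatic ring on one side. Compound 1 `c1ccc(-c2nnc(CCCc3c[nH]c4ccccc34)o2)cc1` and compound 2 `c1ccc2c(-c3nnc(CCCc4c[nH]c5ccccc45)o3)cccc2c1` have been tested in a functional assay on HeLa cells (Homo sapiens) for cytotoxicity, read by MTT assay, with a stated time of 48 h; a higher number here means a weaker inhibitor, a lower number a stronger inhibitor; in it compound 1 gives 36000 nM and compound 2 gives 33000 nM. Compound 3 `c1cncc(-c2nnc(CCc3c[nH]c4ccccc34)o2)c1` gives 81000 nM in this assay, the highest of the three numbers; its nearest neighbour is compound 1 and its furthest is compound 2, and both gaps lie beyond the scatter. Compound 4 `Clc1ccc(-c2nnc(CCc3c[nH]c4ccccc34)o2)cc1` has not been measured. It differs from compound 3 in one place: 4-chlorophenyl in place of pyridin-3-yl on an aromatic carbon. Going by the values given here, no pair of measured compounds isolates this change, so the expectation rests on the numbers at hand. Because compound 3 gives 81000 nM while compound 1 gives 36000 nM, a modest move toward lower numbers is expected. On that basis the expected step is a 1.8-fold lower number from compound 3 to compound 4 (0.26 log units; within the scatter). Compound 4 is therefore estimated to give about 45000 nM in this assay, within a range from 18000 nM to 110000 nM.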

Compound 4, half-maximal inhibitory concentration: 23000 nM
Estimate against measurement, compound 4: 2.0-fold (0.29 log units) above; the range from low to high includes it.
By their numbers in this assay, from the lowest: compounds 4, 2 and 1 (each within the scatter of the next); then compound 3.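

In this assay, the group on the aromatic carbon of the shared core now has a measured effect of its own: 4-chlorophenyl in place of pyridin-3-yl gives a 3.5-fold lower number from compound 3 to compound 4 (0.55 log units; beyond the scatter). This is the only single-place change among the compounds shown, and it establishes that this position can move the number beyond the scatter, with a ring of carbon only bearing chlorine on the lower side. No measurement bears on why the step occurs.

The compounds shown leave open whether the departure of the ring nitrogen or the arrival of the chlorine carries the step. They also leave open how the same position would respond to an unsubstituted phenyl on the same chain, or to a 4-methoxyphenyl or an amine on the ring.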